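Compound 4 against the 3-ethynylphenyl lead

The source may hold more compounds than are shown below. What is called first, only, known or untested is meant among the compounds shown, and "the series" means these compounds.

Measured in a functional assay on A549 cells (Homo sapiens) for antiproliferative activity, read by MTT assay, with a stated time of 72 h; a higher number here means a weaker inhibitor, a lower number a stronger inhibitor:
- compound 1 `C#Cc1cccc(Nc2ncnc3cc(OC)c(OCCCCC(=O)Nc4ccc(S(N)(=O)=O)cc4)cc23)c1` gives 7720 nM
- compound 2 `COc1cc2ncnc(Nc3cccc(Br)c3)c2cc1OCCCCC(=O)Nc1ccc(S(N)(=O)=O)cc1` gives 14900 nM
- compound 3 `COc1cc2ncnc(Nc3ccc(F)cc3)c2cc1OCCCCC(=O)Nc1ccc(S(N)(=O)=O)cc1` gives > 40000 nM, which is a limit of the assay and not a number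

Compound 1 stands with compound 2 at the low end of the numbers in this assay, with a 1.9-fold higher number from compound 1 to compound 2 (0.29 log units; within the scatter). Compound 4 `COc1cc2ncnc(Nc3ccc(Cl)cc3)c2cc1OCCCCC(=O)Nc1ccc(S(N)(=O)=O)cc1` is the next to be tested. It carries 4-chlorophenyl in place of 3-ethynylphenyl on a nitrogen on an aromatic ring. The closest measured change is the one to 4-fluorophenyl, with an at least 5.1-fold higher number from compound 1 to compound 3 (0.71 log units; beyond the scatter) and an at least 2.6-fold higher number from compound 2 to compound 3 (0.42 log units; beyond the scatter). Both of these are minimum sizes only because of the limit of > 40000 nM in this assay, at which 1 of the 3 values shown sits. The swap of bromo for ethynyl in compound 2 left the number within the scatter, but that step does not touch the 4-substituted aryl group. Resting on compound 3 and an at least 5.1-fold higher number from compound 1 to compound 3 (0.71 log units; beyond the scatter), the expectation is a higher number beyond the scatter, a 3.6-fold higher number from compound 1 to compound 4 (0.56 log units; beyond the scatter). Compound 4 is estimated at 28000 nM, with an expected range of 12000 nM to 60000 nM.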

Compound 4, half-maximal inhibitory concentration: > 40000 nM
Compound 4 was reported as a limit; the forecaster's own chance of this, stated with the estimate: 40%; middle value at least 1.4-fold (0.15 log units) away from the limit.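

In this assay compound 4 gives > 40000 nM, which is a limit of the assay and not a number. The 4-chlorophenyl group thus joins the 4-fluorophenyl group of compound 3 on this nitrogen, with an at least 5.1-fold higher number from compound 1 to compound 4 (0.71 log units; beyond the scatter) and an at least 2.6-fold higher number from compound 2 to compound 4 (0.42 log units; beyond the scatter), so the loss is not confined to the fluoro group. The step from compound 3 to compound 4 cannot be read, and the two sizes above are minimums only because of what the assay can report: the limit of > 40000 nM in this assay, at which 2 of the 4 values shown sit.

Compounds 3 and 4 each differ from compounds 1 and 2 in both the substituent and its place on the ring, so a 3-chlorophenyl group would be needed to separate the two. On these data alone, how a shorter chain would alter the numbers of compounds 1 and 2 also remains open.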